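The source may hold more compounds than are shown below. What is called first, only, known or untested is meant among the compounds shown, and "the series" means these compounds.

Compound 1 `CC1=CC[C@@H]([C@@](C)(O)CCCC(C)(C)NC(=S)N/N=C\c2ccccc2)CC1`: 57400 nM
Compound 2 `CC1=CC[C@@H]([C@@](C)(O)CCCC(C)(C)NC(=S)N/N=C\c2ccc(O)cc2)CC1`: 58500 nM

In a functional assay on HT-29 cells (Homo sapiens) for cytotoxicity, read by sulforhodamine B assay (on this read-out higher numbers stand for lower toxicity in this test and lower numbers for higher toxicity in this test), compound 2 and compound 1 stand at numbers that cannot be told apart, since the step of a 1.0-fold higher number from compound 1 to compound 2 (0.01 log units; within the scatter) is within the scatter. Compound 3 `CC1=CC[C@@H]([C@@](C)(O)CCCC(C)(C)NC(=S)N/N=C\c2ccccc2[N+](=O)[O-])CC1` has not been measured; it differs from compound 2 by 2-nitrophenyl in place of 4-hydroxyphenyl on a carbon with a double bond to nitrogen. Among the compounds with values here, the only measured step, hydroxy in place of hydrogen, is not a close match to this replacement, and it was within the scatter, so no step beyond the scatter in this assay is expected. For compound 3 the estimated value is 55000 nM, with a range from 20000 nM to 150000 nM. That corresponds to an expected step of a 1.1-fold lower number from compound 2 to compound 3 (0.03 log units; within the scatter).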

Compound 3, concentration lethal to 50% of the cells: 44400 nM
The estimate for compound 3 lay 1.2-fold (0.09 log units) above the measured number; the range from low to high includes it.
By their numbers in this assay, from the lowest: compounds 3, 1 and 2 (each within the scatter of the next).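

In this assay, nitro in place of hydrogen on an aromatic carbon gives a 1.3-fold lower number from compound 1 to compound 3 (0.11 log units; within the scatter), and 2-nitrophenyl in place of 4-hydroxyphenyl gives a 1.3-fold lower number from compound 2 to compound 3 (0.12 log units; within the scatter). The aromatic group on the carbon with a double bond to nitrogen has thus now carried either of two different substituents with no step beyond the scatter. Nothing available explains this flat result.

Going by these compounds, whether an amine or a carboxylic acid on that aromatic ring would move the number remains open. So does the effect of replacing the ring with a longer chain.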